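The source may hold more compounds than are shown below. What is called first, only, known or untested is meant among the compounds shown, and "the series" means these compounds.

In a functional assay on MIA PaCa-2 cells (Homo sapiens) for inhibition, read by MTT assay, with a stated time of 7 days (on this read-out lower numbers stand for stronger inhibition and higher numbers for weaker inhibition), compound 1 `CCN(CC)S(=O)(=O)c1ccc(S(=O)(=O)N2CCC[C@@H](C(=O)N3CCN(c4nc(C)no4)CC3)C2)cc1` gives 250 nM. Among the compounds with values here, compound 2 `CCN(CC)S(=O)(=O)c1ccc(S(=O)(=O)N2CCC[C@@H](C(=O)N3CCN(c4nnc(C(C)C)o4)CC3)C2)cc1` gives 1800 nM, the higher of the two numbers measured so far, and the single recorded step, a 7.2-fold higher number from compound 1 to compound 2 (0.86 log units; beyond the scatter), separates them. Compound 3 `CCN(CC)S(=O)(=O)c1ccc(S(=O)(=O)N2CCC[C@@H](C(=O)N3CCN(C(=O)OC(C)(C)C)CC3)C2)cc1` carries tert-butoxycarbonyl in place of 5-isopropyl-1,3,4-oxadiazol-2-yl on an amine nitrogen in a ring. Within the data shown here, no measured step exchanges the oxadiazolyl ring for tert-butoxycarbonyl, so the one recorded step offers only an indirect pointer, and the expected shift from compound 2 to compound 3 is a 1.2-fold lower number from compound 2 to compound 3 (0.08 log units; within the scatter), not clearly beyond the scatter. For compound 3 the expected value is 1500 nM, with a range from 300 nM to 8000 nM.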

Compound 3, half-maximal inhibitory concentration: 70 nM
Compound 3: middle estimate off by 21-fold (1.33 log units), on the high side, outside the stated range (below it).
By their numbers in this assay, from the lowest: compound 3; then compound 1; then compound 2.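

Within the data shown here, at this position, on an amine nitrogen in a ring, the earlier compounds carried only oxadiazolyl rings; compound 3 shows that a group with no ring can give a lower number in this assay than either of them, with a 26-fold lower number from compound 2 to compound 3 (1.41 log units; beyond the scatter) and a 3.6-fold lower number from compound 1 to compound 3 (0.55 log units; beyond the scatter). Among these three compounds, then, a five-membered aromatic ring at this place is not required for the lowest number. Nothing available explains this difference. Still open, on these data alone, is whether the tert-butyl part or the carbonyl carries the gain: a methyl carbamate, an acetyl group or the free amine at the same nitrogen would separate the two.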